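The compounds below may be only part of what the source reports. "The series", "measured", "known", "first", "only" and "open" are said of these compounds alone.

For the measured compounds named here, in a functional assay on A549 cells (Homo sapiens) for antiproliferative activity, read by MTT assay, with a stated time of 48 h (a lower number here means a stronger inhibitor, a higher number a weaker inhibitor), compound 1 `Brc1ccc2[nH]c(-c3cn(-c4ccccc4)nc3-c3ccccc3)nc2c1` gives 1810 nM and holds the lower of the two numbers so far, while compound 2 `Clc1cc2nc(-c3cn(-c4ccccc4)nc3-c3ccccc3)[nH]c2cc1Cl` gives 11100 nM and sits higher by a gap beyond the usual scatter. Compound 3 `O=C(OCc1ccccc1)c1ccc2[nH]c(-c3cn(-c4ccccc4)nc3-c3ccccc3)nc2c1` is still unmeasured. It has benzyloxycarbonyl in place of bromo on an aromatic carbon of the core of compound 1 (benzyloxycarbonyl in place of bromo on an aromatic carbon). Going by the values given here, no measured pair shows a change of this kind, so the size of the step remains uncertain. A moderate weakening in this assay is expected, with the estimated step being a 2.2-fold higher number from compound 1 to compound 3 (0.34 log units; beyond the scatter) in a higher number. Compound 3 is estimated at 4000 nM (expected range 1200 nM to 15000 nM).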

Compound 3, half-maximal inhibitory concentration: 19300 nM
Compound 3: middle estimate off by 4.8-fold (0.68 log units), on the low side; measured number outside the range, above it.
By their numbers in this assay, from the lowest: compound 1; then compounds 2 and 3 (each within the scatter of the next).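

In this assay, the step from bromo to benzyloxycarbonyl at this aromatic carbon of the shared core is an 11-fold higher number from compound 1 to compound 3 (1.03 log units; beyond the scatter) and points to weaker inhibition. For the compounds shown here, this is the first single-place comparison here, and it shows that this position is not indifferent to what it carries: the larger group comes with a large loss. No available measurement explains the size of this step. Going by these compounds, it remains open whether the loss comes from the carbonyl portion or from the added aromatic ring, and how a carboxylic acid, a methyl ester or an amine at this position would compare with bromo.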